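A few compounds are considered here, and "the series" means these few. Any claim that something is new, unique, unknown or untested is made for them only; others in the source may bear on it.

Working notes on the series. In a functional assay on BXPC-3 cells (Homo sapiens) for cytotoxicity, read by fluorescence, with a stated time of 48 h (a lower number here means that less compound is needed, a higher number that more compound is needed for the effect), compound 1 (`CC(C)=CCC/C(C)=C/CC/C(C)=C/CSC[C@H](NC(=O)CCCCCN1CCCC1)C(=O)NC1CCCC1`) gives 6800 nM, compound 2 (`CC(C)=CCC/C(C)=C/CC/C(C)=C/CSC[C@H](NC(=O)CCCCCN1CCN(C)CC1)C(=O)NC1CC1`) gives 6300 nM and compound 3 (`CC(C)=CCC/C(C)=C/CC/C(C)=C/CSC[C@H](NC(=O)CCCCCN1CCN(C)CC1)C(=O)N1CCCCC1`) gives 8800 nM, so compound 3 stands within the scatter of both others. Compound 4 (`CC(C)=CCC/C(C)=C/CC/C(C)=C/CSC[C@H](NC(=O)CCCCCN1CCN(C)CC1)C(=O)NC1CCCC1`) has cyclopentylamino in place of piperidin-1-yl on a carbonyl carbon. The nearest measured change is a 1.4-fold higher number from compound 2 to compound 3 (0.15 log units; within the scatter), with piperidin-1-yl in place of cyclopropylamino at that same place. Compound 1 also carries cyclopentylamino and gives 6800 nM. No step beyond the scatter is therefore expected in this assay. The estimated change is a 1.3-fold lower number from compound 3 to compound 4 (0.10 log units; within the scatter). For compound 4 the expected value is 7000 nM, with an estimated range of 3500 nM to 14000 nM.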

Compound 4, half-maximal effective concentration: > 20000 nM
Compound 4 was reported as a limit; the forecaster's own chance of this, stated with the estimate: 3%; middle value at least 2.8-fold (0.45 log units) away from the limit.
By their numbers in this assay, from the lowest: compounds 2, 1 and 3 (each within the scatter of the next). At a limit, above all of these: compound 4.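

In this assay compound 4 is a limit, not a number: the limit of > 20000 nM in this assay, at which 1 of the 4 values shown sits.
At the carbonyl carbon, cyclopentylamino in place of piperidin-1-yl gives a step beyond the scatter (an at least 2.2-fold higher number from compound 3 to compound 4 (0.35 log units; beyond the scatter)), and so does cyclopentyl in place of cyclopropyl on the amide-type nitrogen (an at least 3.1-fold higher number from compound 2 to compound 4 (0.50 log units; beyond the scatter)). Cyclopentylamino alone does not give the limit: the step also depends on 4-methylpiperazin-1-yl in place of pyrrolidin-1-yl at the chain end (an at least 2.9-fold higher number from compound 1 to compound 4 (0.46 log units; beyond the scatter)).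

Still open, going by these compounds, is how cyclopropylamino or piperidin-1-yl on the carbonyl carbon would read with pyrrolidin-1-yl at the chain end, and how an open-chain amine such as dimethylamino would read there.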